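Series notes: aryl exchange on the sulfonyl sulfur

The compounds below may be only part of what the source reports. "The series", "measured", "known", "first", "only" and "open" are said of these compounds alone.

Measured compounds:
Compound 1, `COc1cc2nc(N3CCN(S(=O)(=O)c4ccc(OC(F)(F)F)cc4)CC3)nc(N)c2cc1OC`; in a functional assay on PC-3 cells (Homo sapiens) for inhibition (a higher number here means a weaker inhibitor, a lower number a stronger inhibitor), compound 1 gives 25000 nM.
Compound 2, `COc1cc2nc(N3CCN(S(=O)(=O)c4ccc(C(=O)O)cc4)CC3)nc(N)c2cc1OC`; in this assay compound 2 gives 53000 nM.

Among the measured compounds shown here, compound 2 stands at the highest of the two numbers; the only neighbour is compound 1, and the single step between them, a 2.1-fold higher number from compound 1 to compound 2 (0.33 log units; beyond the scatter), is modest but beyond the scatter.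

Compound 3, `COc1cc2nc(N3CCN(S(=O)(=O)c4cc(Cl)ccc4Cl)CC3)nc(N)c2cc1OC`, differs from compound 2 by 2,5-dichlorophenyl in place of 4-carboxyphenyl on a sulfonyl sulfur. For the measured compounds named here, no measured step covers a dichloro pattern, so the expectation rests on a 2.1-fold higher number from compound 1 to compound 2 (0.33 log units; beyond the scatter) alone, which shows the carboxy-bearing compound 2 at the weaker end of the pair. Taking the carboxy away is the part of the change with any precedent; the entering 2,5-dichlorophenyl has none here. A modest move to a lower number is therefore expected, a 2.1-fold lower number from compound 2 to compound 3 (0.33 log units; beyond the scatter), with wide uncertainty. Compound 3 is estimated at 25000 nM, between 8000 nM and 80000 nM.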

Compound 3, half-maximal inhibitory concentration: 60000 nM
Estimate against measurement, compound 3: 2.4-fold (0.38 log units) below; measured number inside the range.
By their numbers in this assay, from the lowest: compound 1; then compounds 2 and 3 (each within the scatter of the next).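

At the sulfonyl sulfur, the exchange of 4-carboxyphenyl for 2,5-dichlorophenyl in this assay gives a 1.1-fold higher number from compound 2 to compound 3 (0.05 log units; within the scatter), so losing the hydrogen-bond donor and acceptor of the carboxy-bearing group while gaining two chlorines yields no readable difference between these two compounds. The second new step, a 2.4-fold higher number from compound 1 to compound 3 (0.38 log units; beyond the scatter), is modest, and it makes compound 1 the strongest inhibitor of the three, with 4-(trifluoromethoxy)phenyl ahead of both other aryl groups, though only by a small margin. No available evidence bears on why these aryl groups differ or fail to differ.

Still open, going by these compounds, is whether a single chlorine, as in 4-chlorophenyl, would read differently from the 2,5-dichlorophenyl pattern. Also open, on these data alone, is whether an amine on the aryl ring, or a simple alkyl chain in place of the aryl group on the sulfonyl sulfur, would move the number by more than these modest steps.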